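Ring swap on the benzyl arm of the urea series

This account rests on a few compounds, and the source may have more. Where it says the series, first, only, none or still open, it means among the compounds named here.

Measured compounds, with their values in a functional assay on a cell-free system (plasma) with sterol O-acyltransferase, Soat (Rattus norvegicus) as the target; a higher number here means that more compound is needed for the effect, a lower number that less compound is needed:
Compound 1 `CN(C)c1ccc(CN(Cc2cccc(-c3cc[nH]n3)c2)C(=O)Nc2c(F)cc(F)cc2F)cc1` — the assay reports only a limit, < 0.32 mg/kg.
Compound 2 `O=C(Nc1c(F)cc(F)cc1F)N(Cc1ccc(-c2ccsc2)cc1)C1CCCCCC1` — again only a limit, > 1 mg/kg.
Compound 3 `Cc1cc(C)c(NC(=O)N(Cc2ccc(-c3ccsc3)cc2)C2CCCCCC2)c(C)c1` — 0.51 mg/kg.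

For the measured compounds named here, compound 3 thus supplies the only number in this assay; the other two values are limits, the limit of < 0.32 mg/kg in this assay, at which 1 of the 3 values shown sits, and (the limit of > 1 mg/kg in this assay, at which 1 of the 3 values shown sits). Compound 4 `Cc1cc(C)c(NC(=O)N(Cc2ccc(-n3ccnn3)cc2)C2CCCCCC2)c(C)c1` differs from compound 3 by 1H-1,2,3-triazol-1-yl in place of thiophen-3-yl on an aromatic carbon. Going by the values given here, the one measured step, an at least 1.9-fold lower number from compound 2 to compound 3 (0.29 log units; that floor lies within the scatter), concerns the group on the amide-type nitrogen rather than this ring, so no measured step bears directly on the change to compound 4. Compound 1 carries a different five-membered ring and differs in further places, and only its limit is known. In this assay no step beyond the scatter is therefore expected, a 1.2-fold higher number from compound 3 to compound 4 (0.07 log units; within the scatter). Compound 4 is expected near 0.6 mg/kg, within 0.25 mg/kg to 1.5 mg/kg.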

Compound 4, dose for half-maximal effect: > 1 mg/kg
Compound 4 gave a limit, no number; the forecaster's own chance of this, stated with the estimate: 25%; middle value at least 1.6-fold (0.22 log units) away from the limit.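

For the compounds shown here, at the aromatic carbon para to a large group, this assay now gives a first step for a ring change: an at least 1.9-fold higher number from compound 3 to compound 4 (0.29 log units; that floor lies within the scatter). On these data alone, compound 4 gives only a limit, so the true size of this step stays unknown; the swap also takes the hydrogen-bond acceptor count from 1 to 3. Nothing shown accounts for the step. As far as these compounds go, how a phenyl ring or an amine would read on this carbon remains open. So does whether 1H-1,2,3-triazol-1-yl would read differently alongside 2,4,6-trifluorophenyl on the amide-type nitrogen.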